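A few compounds are considered here, and "the series" means these few. Any claim that something is new, unique, unknown or untested is made for them only; others in the source may bear on it.

Among the measured compounds shown here, in an ADME assay on microsomes from liver (Mus musculus, strain CD1) for metabolic stability, read by HPLC, using NADPH, with a stated time of 30 min (a lower number here means slower removal, a higher number faster removal of the compound), compound 2 (`COc1cccc(NC(=O)c2nnn(Cc3ccc(C(C)C)cc3)c2N)c1`) gives 3.2 mL.min-1.g-1 and holds the higher of the two numbers so far, while compound 1 (`COc1cccc(NC(=O)c2nnn(Cc3ccc([S+](C)[O-])cc3)c2N)c1`) gives 0.5 mL.min-1.g-1 in the same measurement. Compound 3 (`COc1cccc(NC(=O)c2nnn(Cc3cc(C)on3)c2N)c1`) has not yet been measured. It differs from compound 2 in one place, on a saturated chain carbon bound to an aromatic nitrogen, where 5-methyl-1,2-oxazol-3-yl stands in place of 4-isopropylphenyl (5-methyl-1,2-oxazol-3-yl in place of 4-isopropylphenyl on a saturated chain carbon bound to an aromatic nitrogen). For the measured compounds named here, the one measured step (a 6.4-fold higher number from compound 1 to compound 2 (0.81 log units; beyond the scatter)) bears on this only loosely: it sits on an aromatic carbon and leaves the ring in place. Going by the values given here, no measured compound carries the entering group, so the guide to size is weak. A move to a lower number in this assay is expected, somewhat smaller than that measured step. The estimated step is a 3.2-fold lower number from compound 2 to compound 3 (0.51 log units; beyond the scatter) and it remains uncertain. The estimate for compound 3 is 1 mL.min-1.g-1 (range 0.4 mL.min-1.g-1 to 2.6 mL.min-1.g-1).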

Compound 3, intrinsic clearance in microsomes: 2.6 mL.min-1.g-1
Estimate against measurement, compound 3: 2.6-fold (0.41 log units) below; the measured number falls inside the stated range.
By their numbers in this assay, from the lowest: compound 1; then compounds 3 and 2 (each within the scatter of the next).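

In this assay, putting 5-methyl-1,2-oxazol-3-yl in place of 4-isopropylphenyl on a saturated chain carbon bound to an aromatic nitrogen gives a 1.2-fold lower number from compound 2 to compound 3 (0.09 log units; within the scatter), so at this place a six-membered aromatic ring of carbon only and a five-membered aromatic ring with 2 hetero atoms cannot be told apart by this read-out. The wider change gives a 5.2-fold higher number from compound 1 to compound 3 (0.72 log units; beyond the scatter), which leaves compound 1 alone at the low end of the three compounds. Nothing measured here accounts for either step.

The compounds shown leave open whether a pyridine ring or a morpholine at this place would give a different number. They also leave open what an amine, a carboxylic acid or a longer chain in place of the methyl of 5-methyl-1,2-oxazol-3-yl would do.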